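Exchanging One Ring Group on a Well-Tolerated Compound

The source may report more compounds than this note shows. Statements on the series, on what has been measured and on what is new or still open speak of the compounds shown alone.

Going by the values given here, only two numbers are available so far. In an ADME assay on CHO cells (Cricetulus griseus) for cytotoxicity, read by MTT assay (a higher number here means that more compound is tolerated, a lower number that less compound is tolerated), compound 1 `FC(F)(F)c1cccc(Nc2cc3[nH]c(Nc4ccc(N5CCN(CC6CC6)CC5)cn4)nc3cn2)c1` gives 1700 nM and compound 2 `O=C(c1ccnc(Nc2nc3cnc(Nc4ccc(F)c(C(F)(F)F)c4)cc3[nH]2)c1)N1CCN(C2CC2)CC1` gives 30000 nM as the half-maximal cytotoxic concentration. Compound 2 holds the higher of the two numbers, and its gap to compound 1 lies beyond the usual scatter of repeated measurements. These two compounds differ in more than one place, so their gap cannot be tied to any single group.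

Compound 3 `C[C@@H]1CN(C(=O)c2ccnc(Nc3nc4cnc(Nc5ccc(F)c(C(F)(F)F)c5)cc4[nH]3)c2)C[C@H](C)O1` differs from compound 2 in one place, where 2,6-dimethylmorpholin-4-yl stands in place of 4-cyclopropylpiperazin-1-yl on a carbonyl carbon (2,6-dimethylmorpholin-4-yl in place of 4-cyclopropylpiperazin-1-yl on a carbonyl carbon). Among the compounds with values here, no measured pair shows this exchange alone, so the guidance is thin. Within the data shown here, a step within the scatter is expected, with a slight lean toward a lower number, since compound 2 at 30000 nM is the higher of only two measured compounds. The expected change is a 1.3-fold lower number from compound 2 to compound 3 (0.10 log units; within the scatter) and it stays within the usual scatter. Compound 3 is expected to read about 24000 nM with a likely range of 8000 nM to 60000 nM when it is measured.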

Compound 3, half-maximal cytotoxic concentration: 30000 nM
The estimate for compound 3 lay 1.3-fold (0.10 log units) below the measured number, within the range that was stated.
By their numbers in this assay, from the lowest: compound 1; then compounds 2 and 3 (each within the scatter of the next).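

Within this assay the exchange of 4-cyclopropylpiperazin-1-yl for 2,6-dimethylmorpholin-4-yl on a carbonyl carbon gives no change at the digits printed from compound 2 to compound 3 (within the scatter) and is the first step here that can be tied to a single group, which the earlier pair, differing in more than one place, could not offer. At this position, then, the three-membered carbon ring can leave, a ring nitrogen can give way to an oxygen, and two defined stereocentres can enter, all with the cell tolerance reading unchanged within the scatter. No measured information on the compounds explains why the number holds through this exchange.

Going by these compounds, one exchange at one position says little about how much freedom this carbonyl carbon allows overall, so it remains open whether a plain morpholine ring, a piperidine ring or an open-chain group such as dimethylamino would read the same. On these data alone, it also remains open whether the other arrangements of the two methyl groups on the morpholine ring would match compound 3.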